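The compounds below may be only part of what the source reports. "The series", "measured", "known", "first", "only" and "open" are said of these compounds alone.

Measured compounds:
compound 1 `COc1ccc(N/C=C\C(=O)c2cn(-c3ccccc3)nc2-c2ccc(F)cc2)cc1`, 19600 nM;
compound 2 `COc1cc(N/C=C\C(=O)c2cn(-c3ccccc3)nc2-c2ccc(F)cc2)cc(OC)c1OC`, 32800 nM;
compound 3 `COc1ccc(N/C=C\C(=O)c2cn(-c3ccccc3)nc2-c2ccc(Cl)cc2)cc1`, 30800 nM.

Three compounds were measured in an ADME assay on HaCaT cells (Homo sapiens) for antiproliferative activity, read by MTT assay, with a stated time of 48 h; a higher number here means a weaker inhibitor, a lower number a stronger inhibitor. Compound 1 `COc1ccc(N/C=C\C(=O)c2cn(-c3ccccc3)nc2-c2ccc(F)cc2)cc1` gives 19600 nM in this assay. Compound 3 `COc1ccc(N/C=C\C(=O)c2cn(-c3ccccc3)nc2-c2ccc(Cl)cc2)cc1` differs from compound 1 by one change, (chloro in place of fluoro on an aromatic carbon), and in this assay compound 3 gives 30800 nM. The step is a 1.6-fold higher number from compound 1 to compound 3 (0.20 log units; within the scatter). Compound 2 `COc1cc(N/C=C\C(=O)c2cn(-c3ccccc3)nc2-c2ccc(F)cc2)cc(OC)c1OC` has a different core from compound 1; the difference between the two cores is not broken down here. In this assay compound 2 gives 32800 nM. The three numbers all lie within the usual scatter of one another, so no order among them can be read.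

Compound 4 `COc1cc(N/C=C\C(=O)c2cn(-c3ccccc3)nc2-c2ccc(Cl)cc2)cc(OC)c1OC` has not been measured in this assay. It differs from compound 2 by chloro in place of fluoro on an aromatic carbon. This is the same change that separates compound 1 from compound 3, made on a different core; the place of the change is described in the same words for both pairs. For the measured compounds named here, the only guide to its size is the step from compound 1 to compound 3, a 1.6-fold higher number from compound 1 to compound 3 (0.20 log units; within the scatter), which is within the scatter. The step from compound 2 to compound 4 in this assay is therefore expected to be of similar size, a 1.5-fold higher number from compound 2 to compound 4 (0.18 log units; within the scatter), a modest rise that rests on compound 1 and compound 3 because a 1.6-fold higher number from compound 1 to compound 3 (0.20 log units; within the scatter) was small. Going by the values given here, with the single precedent and the different core, the range is kept wide. Compound 4 is estimated to give 50000 nM in this assay, expected between 24000 nM and 110000 nM.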

Compound 4, half-maximal inhibitory concentration: 46600 nM
Beside the measured number, compound 4's estimate is 1.1-fold (0.03 log units) above it, and the stated range covers the measured number.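

In this assay, exchanging 4-fluorophenyl for 4-chlorophenyl on the core of compound 2 gives a 1.4-fold higher number from compound 2 to compound 4 (0.15 log units; within the scatter), a step that lies within the scatter. Set beside the earlier step on the core of compound 1, the new step does not differ from it: the same change on two cores in this assay, a 1.6-fold higher number (0.20 log units; within the scatter) from compound 1 to compound 3 and a 1.4-fold higher number (0.15 log units; within the scatter) from compound 2 to compound 4, 1.1-fold (0.04 log units) apart, within the scatter of two such steps. This shows that, across these two pairs, the change carries from one core to the other without any visible difference in size, but each step is itself within the scatter, so the agreement is between two small steps and does not establish a real effect of the change on either core, nor does it show how the change would read on any further core.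

The compounds shown carry only fluoro or chloro at this place, so it stays open what a methyl, a trifluoromethyl, a nitrile or an amine there would give in this assay. From the compounds shown here alone, it also stays open whether the steps would remain this close on a core bearing a carboxylic acid or a longer chain in place of the methoxy groups, and how the same pairs would read in any other assay.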